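Phenethyl Ether in Place of Fluorobenzyl Ether

This account rests on a few compounds, and the source may have more. Where it says the series, first, only, none or still open, it means among the compounds named here.

Among the three measured compounds, compound 3 `Cc1nn(-c2ncnc3nc[nH]c23)c2c1C(OCc1ccc(F)cc1)CC(=O)N2` holds the lowest number in a functional assay on HEK293 cells for agonist activity at G-protein coupled receptor 39 (Homo sapiens), read by scintillation proximity assay and inositol phosphate accumulation, with a stated time of 75 min, in the presence of a further agent that is not named here; on this read-out higher numbers stand for an effect only at larger amounts of compound and lower numbers for an effect already at smaller amounts: compound 3 gives 1 nM, while compound 2 `Cc1nn(-c2ncnc3nc[nH]c23)c2c1C(OCc1ccc(C#N)cc1)CC(=O)N2` gives 4 nM and compound 1 `Cc1nn(-c2ncnc3nc[nH]c23)c2c1C(OCc1ccccc1C#N)CC(=O)N2` gives 8 nM. The steps of a 4.0-fold lower number from compound 2 to compound 3 (0.60 log units; beyond the scatter) and an 8.0-fold lower number from compound 1 to compound 3 (0.90 log units; beyond the scatter) set compound 3 apart from both others, whereas a 2.0-fold lower number from compound 1 to compound 2 (0.30 log units; within the scatter) does not separate compound 1 from compound 2. Compound 4 `Cc1nn(-c2ncnc3nc[nH]c23)c2c1C(OCCc1ccccc1)CC(=O)N2` differs from compound 3 by benzyl in place of 4-fluorophenyl on a saturated chain carbon bound to an oxygen on a saturated carbon. Every measured step swaps the group on the aromatic ring or its position, and none of them lengthens the chain between the oxygen and the ring, so they bear on this change only indirectly: they show that changes at the aryl end move the number by amounts such as a 4.0-fold lower number from compound 2 to compound 3 (0.60 log units; beyond the scatter). Loss of the fluorine together with a further chain carbon has no direct precedent in this set. A modest rise in the number is therefore expected, a 4.0-fold higher number from compound 3 to compound 4 (0.60 log units; beyond the scatter), and compound 4 is estimated at 4 nM, with a range from 1 nM to 20 nM.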

Compound 4, half-maximal effective concentration: 3 nM
Compound 4: the middle estimate sits 1.3-fold (0.12 log units) above what was measured; the range from low to high includes it.
By their numbers in this assay, from the lowest: compound 3; then compounds 4, 2 and 1 (each within the scatter of the next, the first and the last beyond it).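

The change from 4-fluorobenzyl to phenethyl is the first shown here that alters the chain rather than only the aryl end, and at this position it moves the number only modestly, with a 3.0-fold higher number from compound 3 to compound 4 (0.48 log units; beyond the scatter) in this assay. Set against the cyano-bearing ethers, the phenethyl ether gives two different readings: a 1.3-fold lower number from compound 2 to compound 4 (0.12 log units; within the scatter) does not separate the pair, whereas a 2.7-fold lower number from compound 1 to compound 4 (0.43 log units; beyond the scatter) does. Nothing measured here accounts for these steps.

On these data alone, since the fluorine and the chain change together, their separate shares stay open, and the 4-fluorophenethyl ether would address this directly. Also open, as far as these compounds go, is whether a longer chain such as 3-phenylpropyl, or an amine on the aromatic ring, keeps the number this low.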